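Swapping the Aminoethyl Arm for a Thiazole

The compounds below may be only part of what the source reports. "The series", "measured", "known", "first", "only" and "open" are said of these compounds alone.

Measured compounds:
compound 1 `N[C@@]1(C(=O)O)CN(C[C@@H]2COCCN2)C[C@@H]1CCCB(O)O` gives 10 nM in an assay for inhibition of arginase-1 (Homo sapiens), read by colorimetric assay, with a stated time of 60 min, in the presence of a further agent that is not named here; on this read-out lower numbers stand for stronger inhibition and higher numbers for weaker inhibition;
compound 2 `C[C@@H](N)CN1C[C@H](CCCB(O)O)[C@](N)(C(=O)O)C1` gives 16 nM;
compound 3 `C[C@H](N)CN1C[C@H](CCCB(O)O)[C@](N)(C(=O)O)C1` gives 7.7 nM.

Compound 3 holds the lowest number of the three. The step of a 1.3-fold lower number from compound 1 to compound 3 (0.11 log units; within the scatter) lies within the scatter, and the step of a 2.1-fold lower number from compound 2 to compound 3 (0.32 log units; beyond the scatter) is a modest gap that rests on (the fact that compounds 2 and 3 differ only in the configuration as drawn). Compound 4 `N[C@@]1(C(=O)O)CN(Cc2cncs2)C[C@@H]1CCCB(O)O` carries 1,3-thiazol-5-yl in place of 1-aminoethyl on a saturated chain carbon bound to an amine nitrogen in a ring. The measured steps at this position, a 1.6-fold higher number from compound 1 to compound 2 (0.20 log units; within the scatter) and a 1.3-fold lower number from compound 1 to compound 3 (0.11 log units; within the scatter), show that exchanging a six-membered ring group for an open aminoethyl arm moved the number little in either direction; only the configurational pair gave a step beyond the scatter. Going by the values given here, none of the measured compounds carries an aromatic group at this position, so the step to compound 4 is not directly covered. He therefore expects a small to modest change, more likely toward a higher number, as a 1.9-fold higher number from compound 3 to compound 4 (0.29 log units; within the scatter). For compound 4 the estimate is 15 nM, with a range from 5 nM to 50 nM.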

Compound 4, half-maximal inhibitory concentration: 360 nM
The estimate for compound 4 lay 24-fold (1.38 log units) below the measured number; the whole stated range lies below it.
By their numbers in this assay, from the lowest: compounds 3, 1 and 2 (each within the scatter of the next, the first and the last beyond it); then compound 4.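

In this assay, going by these compounds alone, this position proved far less forgiving than the earlier compounds suggested, for the step to the 1,3-thiazol-5-yl group is large from each of them: a 47-fold higher number from compound 3 to compound 4 (1.67 log units; beyond the scatter) and a 23-fold higher number from compound 2 to compound 4 (1.35 log units; beyond the scatter) and also a 36-fold higher number from compound 1 to compound 4 (1.56 log units; beyond the scatter). The open aminoethyl arm and the six-membered non-aromatic ring had stayed close together, so the tolerance seen among compounds 1, 2 and 3 does not extend to this five-membered aromatic ring, which also brings no hydrogen-bond donor to the position. Nothing at hand accounts for the size of this loss.

The compounds shown do not separate the aromatic ring from the missing amine as the source of the loss. An aminomethyl group on the thiazole, or a plain cyclohexyl ring at this position, would be needed to tell the two apart.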